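The compounds below may be only part of what the source reports. "The series", "measured", "known", "first", "only" and "open" are said of these compounds alone.

Three measured compounds share one core and differ in the linker between the ring nitrogen and the furan carbonyl. Compound 1 `COc1cc2nc(NCCCCCCCNC(=O)c3ccco3)nc(N)c2cc1OC` gives 28.8 nM in a functional assay for antagonist activity at Adrenergic receptor alpha-1 (Rattus norvegicus); a higher number here means weaker binding, a lower number tighter binding. Compound 3 `COc1cc2nc(N(C)CCNC(=O)c3ccco3)nc(N)c2cc1OC` gives 9.33 nM in this assay. Compound 2 `COc1cc2nc(N(C)CCCCN(C)C(=O)c3ccco3)nc(N)c2cc1OC` gives 7.08 nM in this assay, the lowest of the three numbers; its gap to compound 3 lies within the scatter, while compound 1 stands beyond the scatter with the higher number.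

Compound 4 `COc1cc2nc(N(C)CCCCCCNC(=O)c3ccco3)nc(N)c2cc1OC` has not been measured. It differs from compound 2 by 2-(((furan-2-yl)carbonyl)amino)ethyl in place of ((furan-2-yl)carbonyl)(methyl)amino on a saturated chain carbon, four bonds along the chain from a nitrogen on an aromatic ring, and the chain is longer, as in compound 1 with 28.8 nM, which gives reason to expect a move toward a higher number. The step of a 2.1-fold higher number from compound 2 to compound 4 (0.33 log units; beyond the scatter) is expected to be modest, in the direction of weaker binding. Compound 4 is estimated at 15 nM, with a range from 6 nM to 40 nM.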

Compound 4, dissociation constant: 2.95 nM
The estimate for compound 4 lay 5.1-fold (0.71 log units) above the measured number; the measured number lies below the stated range.
By their numbers in this assay, from the lowest: compound 4; then compounds 2 and 3 (each within the scatter of the next); then compound 1.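

In this assay, 2-(((furan-2-yl)carbonyl)amino)ethyl in place of ((furan-2-yl)carbonyl)(methyl)amino on a saturated chain carbon gives a 2.4-fold lower number from compound 2 to compound 4 (0.38 log units; beyond the scatter). This position therefore accepts the longer chain with the amide hydrogen, and the number moves toward tighter binding. No measurement offered here explains the step. The change lengthens the chain and removes the methyl on the amide nitrogen together, and the compounds shown do not separate the two. Also open, on these data alone, is how a longer chain, with or without that methyl, would read.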